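Moving the amine on the benzyl ring of compound 1

A few compounds are considered here, and "the series" means these few. Any claim that something is new, unique, unknown or untested is made for them only; others in the source may bear on it.

Compound 1 `COC(=O)c1ccc(NCc2cncn2Cc2ccc(N)cc2)cc1-c1ccccc1`: in a toxicity assay on NIH3T3 cells (Mus musculus) for cytotoxicity, read by resazurin assay (on this read-out lower numbers stand for an effect already at smaller amounts and higher numbers for an effect only at larger amounts of compound), compound 1 gives > 10000 nM
Compound 2 `N#Cc1ccc(NCc2cncn2Cc2ccc(-c3ccccc3)cc2N)cc1-c1ccccc1`: compound 2 gives > 1000 nM
Compound 3 `CCOC(=O)c1ccc(NCc2cncn2Cc2ccc(-c3ccccc3)cc2)cc1-c1ccccc1`: compound 3 gives > 10000 nM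

Every reading here is a limit of the assay rather than a number. Compound 1 stands at the limit of > 10000 nM in this assay, at which 2 of the 3 values shown sit. Compound 3 stands at that same limit. Compound 2 stands at the limit of > 1000 nM in this assay, at which 1 of the 3 values shown sits. Among the measured compounds shown here, compound 1 thus sits at the higher limit, with no number of its own, and no measured pair differs in one place, so no step is known.

Compound 4 `COC(=O)c1ccc(NCc2cncn2Cc2cccc(N)c2)cc1-c1ccccc1` is not yet measured. It differs from compound 1 in that (3-aminophenyl in place of 4-aminophenyl on a saturated chain carbon bound to an aromatic nitrogen). The same atoms are merely joined differently, and the step is expected to be a step that the limit leaves unreadable from compound 1 to compound 4, nothing beyond the scatter. Compound 4 is therefore estimated at 20000 nM, within 8000 nM to 60000 nM, most likely again reported only as a limit.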

Compound 4, half-maximal effective concentration: > 10000 nM
Compound 4 was reported as a limit (the forecaster's own chance of this, stated with the estimate: 85%); the middle value is on the limit's open side.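

Among the compounds shown here, compound 1 and compound 4 are both reported only as limits, and no step between them can be read: the limit of > 10000 nM in this assay, at which 3 of the 4 values shown sit. The compounds shown leave open whether 4-aminophenyl and 3-aminophenyl differ in cytotoxicity at all.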